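From Hydroxamate to Aminobenzamide: What Compound 4 May Show

The source may hold more compounds than are shown below. What is called first, only, known or untested is meant among the compounds shown, and "the series" means these compounds.

Compound 2 `O=C(NO)c1ccc(CNc2nccc(-c3cccnc3)n2)cc1` is the only one of the three measured compounds that gives a number rather than a limit in an assay on isolated protein for inhibition of protein deacetylase HDAC6 (Homo sapiens), read by fluorescence, with stated times of 3 h and 60 min; on this read-out higher numbers stand for weaker inhibition and lower numbers for stronger inhibition; compound 2 gives 42 nM. Compound 1 `Nc1ccccc1NC(=O)c1ccc(CNC2=NC(=O)C(Cc3c[nH]c4ccccc34)N2)cc1` reaches only the limit of the assay, giving > 20000 nM. Compound 3 `CC(C)(C)OC(=O)N1C(NCc2ccc(C(=O)Nc3ccccc3N)cc2)=NC(=O)C1Cc1c[nH]c2ccccc12` likewise stops at the limit, with > 20000 nM. Within the data shown here, the one step measured between them, tert-butoxycarbonyl in place of hydrogen on an amine nitrogen in a ring, is a step that the two limits leave unreadable from compound 1 to compound 3, so it reveals nothing about its size.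

Compound 4 `Nc1cc(Br)ccc1NC(=O)c1ccc(CNc2nccc(-c3cccnc3)n2)cc1` differs from compound 2 by 2-amino-4-bromophenyl in place of hydroxy on an amide-type nitrogen. Among the measured compounds shown here, no measured step covers this exchange directly. For the measured compounds named here, still, compound 1 and compound 3, which like compound 4 carry an amide group instead of the hydroxy group, both sit at the limit of > 20000 nM in this assay, at which 2 of the 3 values shown sit, while compound 2 with its hydroxy group is the only one with a readable number. Compound 4 is therefore expected to inhibit far more weakly, most likely reaching the limit again. The expected step is a 360-fold higher number from compound 2 to compound 4 (2.55 log units; beyond the scatter). The estimate for compound 4 in this assay is 15000 nM, ranging from 3000 nM to 60000 nM.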

Compound 4, half-maximal inhibitory concentration: > 20000 nM
Compound 4: a limit, no number (the forecaster's own chance of this, stated with the estimate: 70%); middle value at least 1.3-fold (0.12 log units) from the limit.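

In this assay, among these compounds, 2-amino-4-bromophenyl in place of hydroxy on the amide-type nitrogen brings an at least 470-fold higher number from compound 2 to compound 4 (2.67 log units; beyond the scatter) and is the first step in this set that can be read, since the earlier one joined two limits. Compound 4 gives > 20000 nM and this is a limit of the assay, not a number, so the step gives only the least size of the loss. On the shared core, this one exchange is thus enough to take a readable inhibitor to the limit, and compound 2 is now the only compound that stands apart from the others: the limit of > 20000 nM in this assay, at which 3 of the 4 values shown sit.

Going by these compounds, how far past the limit compound 4 lies remains open. Also open, on these data alone, is what a methoxy group, an amine or a plain phenyl group would give in place of hydroxy at this place on the same core.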